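The compounds below may be only part of what the source reports. "The series", "measured", "known", "first", "only" and "open" are said of these compounds alone.

Measured so far in a functional assay on brain (Rattus norvegicus, strain Wistar) for inhibition; a lower number here means a stronger inhibitor, a higher number a weaker inhibitor:

- compound 1, `CCCCn1c(-c2ccccc2)c(C)[nH]c1=O`, returns only a limit, > 100000 nM.
- compound 2, `Cc1[nH]c(=O)n(C2CCCCC2)c1-c1ccccc1`, gives 47600 nM.
- compound 3, `Cc1[nH]c(=O)n(C2CCCCC2)c1-c1ccccc1OC(C)C`, gives 21500 nM.

Among the two proper numbers, compound 2 stands highest; the step of a 2.2-fold lower number from compound 2 to compound 3 (0.35 log units; beyond the scatter) is modest but beyond the scatter. The value of compound 1 is a limit (the limit of > 100000 nM in this assay, at which 1 of the 3 values shown sits), not a number. Against it, the step of an at least 2.1-fold lower number from compound 1 to compound 2 (0.32 log units; beyond the scatter) is known only as a lower bound.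

The next compound, compound 4, is `CCCCCCCc1ccc(-c2c(C)[nH]c(=O)n2C2CCCCC2)cc1`. Its difference from compound 2 is heptyl in place of hydrogen on an aromatic carbon. For the measured compounds named here, the closest precedent is the step from compound 2 to compound 3, where a new group on an aromatic carbon of the same ring gave a modest lowering; the step from compound 1 to compound 2 concerns the aromatic nitrogen and bears less directly. Both measured changes moved the number downward, neither by a large amount. Going by the values given here, a change of similar kind, a heptyl chain entering on an aromatic carbon, is therefore expected to lower the number in this assay by a modest to moderate amount, with a wide spread because only one step on this ring is available. Compound 4 is expected at about 12000 nM, between 3500 nM and 40000 nM. For compound 4 the expected step is a 4.0-fold lower number from compound 2 to compound 4 (0.60 log units; beyond the scatter).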

Compound 4, half-maximal inhibitory concentration: 8700 nM
Beside the measured number, compound 4's estimate is 1.4-fold (0.14 log units) above it; low and high end bracket the measured number.
By their numbers in this assay, from the lowest: compound 4; then compound 3; then compound 2. At a limit, above all of these: compound 1.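

In this assay, heptyl on an aromatic carbon, para to a large group, brings a 5.5-fold lower number from compound 2 to compound 4 (0.74 log units; beyond the scatter), so this ring takes a long chain with no loss of inhibition. Together with a 2.2-fold lower number from compound 2 to compound 3 (0.35 log units; beyond the scatter), this gives two different groups on the same ring that each lower the number, and the heptyl step shows that a group with no hydrogen-bond donors or acceptors is enough for such a lowering. Nothing measured on these compounds accounts for the size of the heptyl step.

From the compounds shown here alone, whether the lowering follows chain length stays open: a shorter chain such as propyl, a longer chain such as decyl, or an amine or a carboxylic acid at the end of the chain would test it at this place. Compound 1 returns only a limit, > 100000 nM, and whether heptyl would also lower the number with butyl on the aromatic nitrogen remains unsettled.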